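Shifting a Hydroxyphenyl Group and Topoisomerase Inhibition

A few compounds are considered here, and "the series" means these few. Any claim that something is new, unique, unknown or untested is made for them only; others in the source may bear on it.

Compound 1 `Oc1ccc(-c2cc(-c3ccco3)cc(-c3ccccc3O)n2)cc1`: 0%
Compound 2 `Oc1ccc(-c2cc(-c3ccco3)cc(-c3cccc(O)c3)n2)cc1`: 1.5%
Compound 3 `Oc1ccccc1-c1cc(-c2ccccn2)cc(-c2ccccc2O)n1`: "not determined" (no result reported)

In an assay on isolated protein for inhibition of DNA topoisomerase 1 (Homo sapiens), with a stated time of 30 min, tested at 20 uM (on this read-out lower numbers stand for a weaker effect and higher numbers for a stronger effect at the one concentration tested), compound 1 gives 0%, and compound 2 gives 1.5%. The two differ in one place, (3-hydroxyphenyl in place of 2-hydroxyphenyl on an aromatic carbon), and the step of a number 1.5 percentage points higher from compound 1 to compound 2 (within the scatter).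

Compound 3 has no result in this assay. How its core differs from that of compound 1 is not broken down here. Compound 4 `Oc1cccc(-c2cc(-c3ccccn3)cc(-c3ccccc3O)n2)c1` is related to compound 3 by 3-hydroxyphenyl in place of 2-hydroxyphenyl on an aromatic carbon. This is the same kind of change as that from compound 1 to compound 2, not the same: in compound 1 the place is meta to a 4-hydroxyphenyl group and meta to a furan-2-yl group, while in compound 3 it is meta to a 2-hydroxyphenyl group and meta to a pyridin-2-yl group.

With no number for compound 3, the expectation for compound 4 rests only on compound 1 at 0% and compound 2 at 1.5%, both near the bottom of the scale, and on the step between them lying within the scatter. Compound 4 is therefore estimated to give 3% in this assay, expected to fall between -5% and 15%.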

Compound 4, a percentage reported as inhibition, at one concentration (the size of the read-out at that concentration, not a potency): 0.1%
Compound 4: the middle estimate sits 2.9 percentage points above what was measured; the measured number falls inside the stated range.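

For the compounds shown here, compound 4 gives 0.1% but compound 3 has no number to set against it, so no step between compound 3 and compound 4 can be read. The compounds shown leave open whether 3-hydroxyphenyl in place of 2-hydroxyphenyl changes anything on the core of compound 3. Nothing shown here offers an explanation for these readings.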